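A few compounds are considered here, and "the series" means these few. Any claim that something is new, unique, unknown or untested is made for them only; others in the source may bear on it.

Going by the values given here, in a functional assay on G55T2 cells (Homo sapiens) for antiproliferative activity, read by WST assay, with a stated time of 72 h (on this read-out lower numbers stand for stronger inhibition and higher numbers for weaker inhibition), compound 1 `Cc1cc(C)cc(C(=O)N(CCC(=O)NCc2ccccc2)Cc2ccc(C(=O)NO)cc2)c1` gives 4250 nM and compound 2 `CN(C)c1ccc(C(=O)N(CCC(=O)NCc2ccccc2)Cc2ccc(C(=O)NO)cc2)cc1` gives 1150 nM, the lower of the two numbers so far. Compound 3 `COc1ccc(C(=O)N(CCC(=O)NCc2ccccc2)Cc2ccc(C(=O)NO)cc2)cc1` keeps the shared core and changes one group: methoxy in place of dimethylamino on an aromatic carbon. It carries methoxy in place of dimethylamino on an aromatic carbon, para to a large group. Among the compounds with values here, only one measured step bears on this change, a 3.7-fold lower number from compound 1 to compound 2 (0.57 log units; beyond the scatter), which is modest but beyond the usual scatter. Within the data shown here, it shows that swapping the group on this carbonyl carbon can move the number, but no measured compound yet carries 4-methoxyphenyl there. Among the measured compounds shown here, compound 2 also holds the lowest number so far, so a small move upward is the likeliest outcome. The expected change is a 1.7-fold higher number from compound 2 to compound 3 (0.22 log units; within the scatter). For compound 3, the estimated value is 1900 nM, with an expected range of 800 nM to 4500 nM.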

Compound 3, half-maximal inhibitory concentration: 3490 nM
Beside the measured number, compound 3's estimate is 1.8-fold (0.26 log units) below it; the measured number falls inside the stated range.
By their numbers in this assay, from the lowest: compound 2; then compounds 3 and 1 (each within the scatter of the next).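

In this assay, going by these compounds alone, methoxy in place of dimethylamino gives a 3.0-fold higher number from compound 2 to compound 3 (0.48 log units; beyond the scatter) while the rest of the molecule stays unchanged, so the single group on this aromatic carbon, para to a large group, can move the number by itself. Compared with the 3,5-dimethylphenyl group, 4-methoxyphenyl gives a 1.2-fold lower number from compound 1 to compound 3 (0.09 log units; within the scatter) and so does not separate from it, which leaves 4-(dimethylamino)phenyl as the only one of the three groups on this carbonyl carbon that stands apart from the other two. No measurement shown here explains why dimethylamino and methoxy differ. As far as these compounds go, it remains open whether a plain amino group or a carboxylic acid on this aromatic carbon would fall with dimethylamino or with methoxy. Diethylamino, with longer chains on the nitrogen, is equally open.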